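Cytotoxicity limits and a chloro-for-dimethylamino change

This account rests on a few compounds, and the source may have more. Where it says the series, first, only, none or still open, it means among the compounds named here.

Compound 3 `CCn1cc(C(=O)N2N=C(c3cc4ccccc4o3)CC2c2ccc(N(C)C)cc2)c(=O)c2ccc(C)nc21` stands only at a limit among the numbers shown. In an ADME assay on Vero cells (Chlorocebus sabaeus) for cytotoxicity, read by MTT assay, with a stated time of 72 h (a higher number here means a weaker inhibitor, a lower number a stronger inhibitor), compound 3 gives > 206000 nM, a limit of the assay and not a number. The two other values shown are limits as well. Compound 1 `O=C(c1ccncc1)N1N=C(c2cc3ccccc3o2)CC1c1cccc([N+](=O)[O-])c1` gives > 240000 nM in this assay, a limit. Compound 2 `O=C(c1ccncc1)N1N=C(c2cc3ccccc3o2)CC1c1ccco1` gives > 208000 nM in this assay, also a limit. The step that the two limits leave unreadable from compound 1 to compound 2 therefore cannot be read. Compound 4 `CCn1cc(C(=O)N2N=C(c3cc4ccccc4o3)CC2c2ccc(Cl)cc2)c(=O)c2ccc(C)nc21` differs from compound 3 by chloro in place of dimethylamino on an aromatic carbon. Within the data shown here, no measured step covers this change; the only evidence is that every value sits at a limit (the limit of > 206000 nM in this assay, at which 1 of the 3 values shown sits, (the limit of > 208000 nM in this assay, at which 1 of the 3 values shown sits), (the limit of > 240000 nM in this assay, at which 1 of the 3 values shown sits)). Compound 4 is therefore expected to show no step beyond the scatter, a step that the limit leaves unreadable from compound 3 to compound 4. Compound 4 is estimated at 250000 nM, with a range from 100000 nM to 600000 nM, most likely again reported as a limit.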

Compound 4, half-maximal inhibitory concentration: > 160000 nM
Compound 4 ended at the assay's limit; the forecaster's own chance of this, stated with the estimate: 85%; the middle value is on the limit's open side.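

Among these compounds, compound 3 and compound 4 both stand only at limits, so the change from dimethylamino to chloro gives no step that can be read. The compounds shown leave open whether any of this series would give an actual number rather than a limit in this assay.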